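The compounds below may be only part of what the source reports. "The series", "measured", "known", "first", "only" and "open" are said of these compounds alone.

Compound 1 `Cc1cc(C)c(NC(=O)N(Cc2c[nH]c(-c3ccccc3)n2)C2CCCCCC2)c(C)c1` gives in a functional assay on a cell-free system (plasma) with sterol O-acyltransferase, Soat (Rattus norvegicus) as the target (on this read-out lower numbers stand for an effect already at smaller amounts and higher numbers for an effect only at larger amounts of compound), a limit of the assay, > 1 mg/kg. Compound 2 `O=C(Nc1c(F)cc(F)cc1F)N(Cc1ccccc1)Cc1cccc(-c2cc[nH]n2)c1` gives 0.096 mg/kg in this assay. Compound 3 `COc1ccc(CN(Cc2cccc(-c3cc[nH]n3)c2)C(=O)Nc2c(SC)cc(C)nc2SC)cc1` likewise sits at a limit of this assay, < 0.1 mg/kg. For compound 3 this limit is all that is known, noted as the limit of < 0.1 mg/kg in this assay, at which 1 of the 3 values shown sits; the other limit in the set is the limit of > 1 mg/kg in this assay, at which 1 of the 3 values shown sits. Compound 4 `CSc1cc(C)nc(SC)c1NC(=O)N(Cc1ccc(F)cc1)Cc1cccc(-c2cc[nH]n2)c1` is not yet measured and differs from compound 3 by fluoro in place of methoxy on an aromatic carbon. Within the data shown here, no measured pair shows this change, so no step beyond the scatter is expected in either direction in this assay. Compound 4 is expected to give about 0.08 mg/kg in this assay, between 0.03 mg/kg and 0.2 mg/kg. The step this estimate implies, a step that the limit leaves unreadable from compound 3 to compound 4, is expected to stay within the scatter.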

Compound 4, dose for half-maximal effect: < 0.1 mg/kg
Compound 4: only a limit was reported; the forecaster's own chance of this, stated with the estimate: 50%; the middle value lies beyond the limit too.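

No step can be read between compound 3 and compound 4, since both sit at the same limit: the limit of < 0.1 mg/kg in this assay, at which 2 of the 4 values shown sit.

The compounds shown leave open whether fluoro in place of methoxy shifts the effect at all.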